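This account rests on a few compounds, and the source may have more. Where it says the series, first, only, none or still open, it means among the compounds named here.

Within the data shown here, in a functional assay on MDA-MB-231 cells (Homo sapiens) for antiproliferative activity, read by MTT assay, with a stated time of 48 h (on this read-out higher numbers stand for weaker inhibition and lower numbers for stronger inhibition), only two compounds have been measured so far. Compound 1 (`C=CS(=O)(=O)N1CCN(c2ncnc3sc(-c4ccc(C(F)(F)F)cc4)cc23)CC1`) reads 6410 nM and compound 2 (`CN1CCN(c2ccc(-c3cc4c(N5CCN(C(=O)Nc6ccccc6)CC5)ncnc4s3)cc2)CC1`) reads 7590 nM on the same scale, so compound 2 stands level with compound 1 within the usual scatter of repeated measurements. Compound 3 (`COc1ccccc1NC(=O)N1CCN(c2ncnc3sc(-c4ccc(N5CCN(C)CC5)cc4)cc23)CC1`) differs from compound 2 by a single change (methoxy in place of hydrogen on an aromatic carbon): methoxy in place of hydrogen on an aromatic carbon, ortho to a large group, which turns phenylcarbamoyl into (2-methoxyphenyl)carbamoyl. Among the measured compounds shown here, no pair of measured compounds shows what such a change does, so in this assay no step beyond the scatter is expected. The estimated step (a 1.5-fold lower number from compound 2 to compound 3 (0.18 log units; within the scatter)) is therefore a small one. For compound 3 the expected value is 5000 nM as the middle of an estimated range from 1800 nM to 14000 nM for repeated measurements.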

Compound 3, half-maximal inhibitory concentration: 23200 nM
Compound 3: the middle estimate sits 4.6-fold (0.67 log units) below what was measured, outside the stated range (above it).
By their numbers in this assay, from the lowest: compounds 1 and 2 (each within the scatter of the next); then compound 3.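

In this assay, methoxy in place of hydrogen on the aromatic ring of the phenylcarbamoyl group, ortho to a large group, brings a 3.1-fold higher number from compound 2 to compound 3 (0.49 log units; beyond the scatter), so inhibition is weaker with methoxy at this position. Among these compounds, this is the first step that lies beyond the scatter, and it shows that the ring of the phenylcarbamoyl group does not accept every substituent without a loss. Nothing at hand accounts for the size of this step.

The compounds shown leave open whether fluorine, a hydroxyl or an amine at the same position would read closer to compound 2 or to compound 3. They also leave open whether methoxy on another carbon of that ring would weaken inhibition to the same extent.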